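Nitrophenyl placement in the bis-benzylidene cyclohexanone series

This account rests on a few compounds, and the source may have more. Where it says the series, first, only, none or still open, it means among the compounds named here.

The series rests on one core, carried by compound 1 `CN(C)c1ccc(/C=C2\CCC/C(=C\c3ccccc3[N+](=O)[O-])C2=O)cc1`, compound 2 `Cc1ccc(/C=C2\CCC/C(=C\c3ccccc3[N+](=O)[O-])C2=O)cc1` and compound 3 `O=C1/C(=C/c2ccccc2)CCC/C1=C\c1ccccc1[N+](=O)[O-]`. In a physicochemical assay for lipophilicity (a higher number here means a more lipophilic compound, a lower number a more polar compound), compound 1 gives 4.86, compound 2 gives 4.86 and compound 3 gives 4.86. Compound 1 is thus level with the other two at the digits shown; the steps of no change at the digits printed from compound 1 to compound 2 (within the scatter) and no change at the digits printed from compound 1 to compound 3 (within the scatter) sit within the scatter, as does no change at the digits printed from compound 2 to compound 3 (within the scatter).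

Compound 4 `CN(C)c1ccc(/C=C2\CCC/C(=C\c3cccc([N+](=O)[O-])c3)C2=O)cc1` is still to be measured in this assay. It differs from compound 1 in one place: 3-nitrophenyl in place of 2-nitrophenyl on a double-bonded chain carbon bound to a double-bonded ring carbon. The two compounds hold the same atoms, joined differently.

Going by the values given here, none of the measured steps touches this place: all three swap a group on the other aromatic ring, and each of them, no change at the digits printed from compound 1 to compound 2 (within the scatter), no change at the digits printed from compound 1 to compound 3 (within the scatter) and no change at the digits printed from compound 2 to compound 3 (within the scatter), stayed within the scatter. The step from compound 1 to compound 4 moves the nitro group within the same ring and neither adds nor removes atoms, so no change beyond the scatter is expected in this assay, with the step of no change at the digits printed from compound 1 to compound 4 (within the scatter) taken as the expectation. Compound 4 is therefore estimated at 4.86, within the range 4.46 to 5.26.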

Compound 4, partition coefficient: 5.06
The estimate for compound 4 lay 0.20 log units below the measured number; the range from low to high includes it.
By their numbers in this assay, from the lowest: compounds 1, 2, 3 and 4 (each within the scatter of the next).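

The nitro-bearing ring now has a reading of its own: with 3-nitrophenyl in place of 2-nitrophenyl on a double-bonded chain carbon bound to a double-bonded ring carbon, this assay gives a number 0.20 log units higher from compound 1 to compound 4 (within the scatter). Going by these compounds alone, the earlier steps all swapped a group on the other aromatic ring and left the printed digits identical, so this is the first step at this place and the first with any difference in the digits, yet compound 1 and compound 4, which hold the same atoms joined differently, remain within the scatter of each other. No supporting data bear on this result.

The compounds shown leave open whether 3-nitrophenyl would give the same picture with methyl or hydrogen in place of dimethylamino on the other aromatic ring, since this place has been read only with dimethylamino present. They also leave open whether a group other than nitro on this ring, such as a nitrile, an amine or a carboxylic acid, would stay within the scatter of compound 1 in this assay.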